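This account rests on a few compounds, and the source may have more. Where it says the series, first, only, none or still open, it means among the compounds named here.

Among the measured compounds shown here, compound 3, `O=C(NC1CCC(CN2CCN(c3cc(=O)c4cc(C(F)(F)F)cc([N+](=O)[O-])c4s3)CC2)CC1)c1ccccc1`, is the one member of this small set that gives an actual number: in an ADME assay on Vero cells (Chlorocebus sabaeus) for cytotoxicity, read by MTT assay, with a stated time of 48 h (a higher number here means a weaker inhibitor, a lower number a stronger inhibitor), compound 3 gives 44.3 ug/mL. Its two neighbours sit at the edge of what the test can report. Compound 1, `COc1ccccc1C(=O)OC1CCC(CN2CCN(c3cc(=O)c4cc(C(F)(F)F)cc([N+](=O)[O-])c4s3)CC2)CC1`, gives in this assay only a limit, > 64 ug/mL. Compound 2, `O=C(OC1CCC(CN2CCN(c3cc(=O)c4cc(C(F)(F)F)cc([N+](=O)[O-])c4s3)CC2)CC1)c1ccco1`, likewise gives in this assay only a limit, > 64 ug/mL. So compound 3 stands as the sole measured value, while both others rest at the limit of > 64 ug/mL in this assay, at which 2 of the 3 values shown sit.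

Compound 4, `O=C(OC1CCC(CN2CCN(c3cc(=O)c4cc(C(F)(F)F)cc([N+](=O)[O-])c4s3)CC2)CC1)c1ccc2c(c1)OCC2`, changes compound 3 in one place: a group of 12 heavy atoms (9 carbon, 3 oxygen; one five-membered non-aromatic ring with 1 hetero atom, one six-membered aromatic ring of carbon only) in place of a group of 9 heavy atoms (7 carbon, 1 nitrogen, 1 oxygen; one six-membered aromatic ring of carbon only), on a saturated ring carbon. The benzamido group leaves, and the entering group, like the ((2-methoxyphenyl)carbonyl)oxy group of compound 1 and the ((furan-2-yl)carbonyl)oxy group of compound 2, is joined through a carbonyl and an oxygen. For the measured compounds named here, two measured steps bear on this change. Going the other way, toward the benzamido group, gave an at least 1.4-fold lower number from compound 1 to compound 3 (0.15 log units; that floor lies within the scatter) and an at least 1.4-fold lower number from compound 2 to compound 3 (0.15 log units; that floor lies within the scatter), both with a floor that lies within the scatter. Reversing that direction, the number for compound 4 is expected to move up toward the limit, or to stay within the scatter. The step of a 1.4-fold higher number from compound 3 to compound 4 (0.13 log units; within the scatter) is the expected outcome of that reasoning. Compound 4 is therefore estimated at 60 ug/mL, with a range from 30 ug/mL to 120 ug/mL, and a real chance that only a limit is reported.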

Compound 4, half-maximal inhibitory concentration: > 64 ug/mL
Compound 4: no number, only a limit (the forecaster's own chance of this, stated with the estimate: 55%); middle value at least 1.0-fold (0.02 log units) away from the limit.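

With compound 4, a third group joined through a carbonyl and an oxygen on the saturated ring carbon reaches the ceiling of this assay, leaving compound 3, with its benzamido group, as the only compound with an actual number: the limit of > 64 ug/mL in this assay, at which 3 of the 4 values shown sit.

The new step, an at least 1.4-fold higher number from compound 3 to compound 4 (0.15 log units; that floor lies within the scatter), has a floor no larger than the scatter, so even this third limit does not establish a real difference between the benzamido group and the oxygen-linked groups, although compounds 1, 2 and 4 all share the limit and compound 3 alone goes against that pattern. The steps among compounds 1, 2 and 4 have limits at both ends and cannot be read, so the change from one ring group to another on the carbonyl carbon remains without a measured size in this set.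

Compound 3 is the only nitrogen-linked member shown, so it remains open whether a furan-2-yl or 2-methoxyphenyl carbonyl joined through nitrogen would also give a number rather than a limit. Also open, as far as these compounds go, is how a plain amine or a carboxylic acid on the same saturated ring carbon would read in this assay.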